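A few compounds are considered here, and "the series" means these few. Any claim that something is new, unique, unknown or untested is made for them only; others in the source may bear on it.

Measured in an ADME assay on BCBL1 cells (Homo sapiens) for cytotoxicity, with a stated time of 7 days; on this read-out lower numbers stand for higher toxicity in this test and higher numbers for lower toxicity in this test:
- compound 1 `CNc1nc(N)nc2c1ncn2/C=C1/CC1(CO)CO`: 67000 nM
- compound 2 `Nc1nc(OCC(F)(F)F)c2ncn(/C=C3/CC3(CO)CO)c2n1`: > 20000 nM (a limit)
- compound 3 `CN(C)c1nc(N)nc2c1ncn2/C=C1/CC1(CO)CO`: > 20000 nM (a limit)

Compound 3 has no exact number, only a limit. Compound 2 and compound 3 both stand at the limit of > 20000 nM in this assay, at which 2 of the 3 values shown sit.

The next analogue, compound 4 `CC(C)Nc1nc(N)nc2c1ncn2/C=C1/CC1(CO)CO`, has not yet been measured. It differs from compound 3 as follows: isopropylamino in place of dimethylamino on an aromatic carbon. In words, isopropylamino replaces dimethylamino on an aromatic carbon.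

The measured steps give little guidance on size. The closest is a step that the limit leaves unreadable from compound 1 to compound 3, and the others are a step that the limit leaves unreadable from compound 1 to compound 2 and a step that the two limits leave unreadable from compound 2 to compound 3. Among the measured compounds shown here, the only exact number is for compound 1, which carries methylamino at that place and gives 67000 nM in this assay. Compound 4 is therefore expected to show low toxicity in this test too, and it may well return only a limit.

The expected size is a step that the limit leaves unreadable from compound 3 to compound 4, an estimate with no firm direction behind it. For compound 4 the estimated value is 40000 nM, with an expected range from 15000 nM to 100000 nM.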

Compound 4, half-maximal cytotoxic concentration: > 20000 nM
Compound 4 ended at the assay's limit; the forecaster's own chance of this, stated with the estimate: 55%; the middle value is on the limit's open side.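

Compound 4 joins compound 2 and compound 3 at a limit, so no step among these compounds or from compound 1 to any of them can be read: the limit of > 20000 nM in this assay, at which 3 of the 4 values shown sit.

The compounds shown leave open how far the true values of compound 2, compound 3 and compound 4 lie from that of compound 1 in this assay.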